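Amide-side aryl swap on a chlorophenyl thioether at the limit

The source may hold more compounds than are shown below. What is called first, only, known or untested is meant among the compounds shown, and "the series" means these compounds.

Compound 1 `Cc1cc(C)cc(C(=O)Nc2nc3ccc(NC(=O)CSc4ccc(Cl)cc4)cc3s2)c1` carries a 4-chlorophenyl on a sulfur and a 3,5-dimethylphenyl on a carbonyl carbon. In a functional assay on U2OS cells (Homo sapiens) for antiproliferative activity, read by MTT assay, with a stated time of 72 h (a lower number here means a stronger inhibitor, a higher number a weaker inhibitor), compound 1 gives > 100000 nM; this is a limit of the assay rather than a measured number, (the limit of > 100000 nM in this assay, at which 1 of the 3 values shown sits). Compound 3 `Cc1cc(C)cc(C(=O)Nc2nc3ccc(NC(=O)CSc4cccc(O)c4)cc3s2)c1` keeps the carbonyl side and differs from compound 1 only by 3-hydroxyphenyl in place of 4-chlorophenyl on a sulfur; in this assay compound 3 gives 2820 nM, giving an at least 35-fold lower number from compound 1 to compound 3 (1.54 log units; beyond the scatter). For the measured compounds named here, compound 2 `O=C(CSc1ncccn1)Nc1ccc2nc(NC(=O)c3ccc(C(F)(F)F)cc3)sc2c1` differs from both in two places and in this assay gives 28100 nM; no single step links it to compound 1 or compound 3.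

Compound 4 `O=C(CSc1ccc(Cl)cc1)Nc1ccc2nc(NC(=O)c3ccc(F)cc3)sc2c1` differs from compound 1 in one place: 4-fluorophenyl in place of 3,5-dimethylphenyl on a carbonyl carbon. Going by the values given here, none of the measured steps touches the carbonyl side; the one measured step alters the sulfur side, and the 4-chlorophenyl on a sulfur stays in compound 4. Among the compounds with values here, no measured step therefore bears on this change, and the numbers give no direction for it. The starting point is a limit, so any step from compound 1 can only be read against that bound. Compound 4 is expected to remain near that limit, with an at least 1.2-fold lower number from compound 1 to compound 4 (0.09 log units; that floor lies within the scatter) as the estimated step. The estimate for compound 4 in this assay is 80000 nM, within 15000 nM to 200000 nM.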

Compound 4, half-maximal inhibitory concentration: 2510 nM
Beside the measured number, compound 4's estimate is 32-fold (1.50 log units) above it, outside the stated range (below it).
By their numbers in this assay, from the lowest: compounds 4 and 3 (each within the scatter of the next); then compound 2. At a limit, above all of these: compound 1.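

The carbonyl side of the series now shows a clear effect in this assay: with the 4-chlorophenyl on a sulfur held fixed, 4-fluorophenyl in place of 3,5-dimethylphenyl on a carbonyl carbon gives an at least 39-fold lower number from compound 1 to compound 4 (1.60 log units; beyond the scatter). For the compounds shown here, until now the only single change measured lay on the sulfur side, as an at least 35-fold lower number from compound 1 to compound 3 (1.54 log units; beyond the scatter), so a single change on either side is now seen to move compound 1 away from its limit. The true size of the new step stays unknown, since it is only a floor and compound 1 stands at a limit of the assay: the limit of > 100000 nM in this assay, at which 1 of the 4 values shown sits.

As far as these compounds go, how the carbonyl-side and sulfur-side changes combine remains open. The compounds shown do not pair 4-fluorophenyl on the carbonyl carbon with 3-hydroxyphenyl on a sulfur. Also open, from the compounds shown here alone, are whether the step follows from losing the two methyl groups or from gaining the fluorine, and whether an amine or a carboxylic acid on that carbonyl-side ring would hold the number of compound 4, 2510 nM.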